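The source may hold more compounds than are shown below. What is called first, only, known or untested is meant among the compounds shown, and "the series" means these compounds.

In a functional assay on MDA-MB-231 cells (Homo sapiens) for antiproliferative activity, read by MTT assay, with a stated time of 72 h (on this read-out higher numbers stand for weaker inhibition and lower numbers for stronger inhibition), compound 1 (`O=C(CCc1cccc2c1B(O)OC2)Nc1cccc(-c2ccc(Cl)cc2)c1`) gives 260 nM as its value. Compound 2 (`O=C(CCc1cccc2c1B(O)OC2)Nc1cccc(-c2cccc(OC(F)(F)F)c2)c1`) gives 460 nM on the same read-out, which places it within the usual scatter of compound 1, so the pair cannot be ranked. Within the data shown here, no step between measured compounds that differ in one place is available, and the data therefore offer no direct size for a single substituent swap. Compound 3 (`CC(=O)c1cccc(-c2cccc(NC(=O)CCc3cccc4c3B(O)OC4)c2)c1`) comes from compound 2 by acetyl in place of trifluoromethoxy on an aromatic carbon. With only compound 1 at 260 nM and compound 2 at 460 nM as guides, a small step in this assay is expected, towards slightly weaker inhibition and not beyond the scatter. The expected change is a 1.3-fold higher number from compound 2 to compound 3 (0.12 log units; within the scatter) and nothing larger than a modest shift is estimated. For compound 3 the estimated value is 600 nM with an expected range from 200 nM to 1800 nM on this read-out.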

Compound 3, half-maximal inhibitory concentration: 52 nM
Compound 3: middle estimate off by 12-fold (1.06 log units), on the high side; measured number below the stated range.
By their numbers in this assay, from the lowest: compound 3; then compounds 1 and 2 (each within the scatter of the next).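

In this assay, acetyl in place of trifluoromethoxy on an aromatic carbon, meta to a large group, gives an 8.8-fold lower number from compound 2 to compound 3 (0.95 log units; beyond the scatter); this position therefore responds clearly to the group it carries, which compound 1 and compound 2, within the scatter of each other, could not show. The change of the whole aryl group, 3-acetylphenyl in place of 4-chlorophenyl, gives a 5.0-fold lower number from compound 1 to compound 3 (0.70 log units; beyond the scatter), so compound 3 stands apart from both earlier compounds, with the lowest number of the three. Both trifluoromethoxy and acetyl count one hydrogen-bond acceptor, so that count does not separate them, while acetyl brings fewer heavy atoms and a double bond outside aromatic rings, and no measurement at hand bears on what lies behind the step.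

As far as these compounds go, it remains open whether the step belongs to acetyl specifically or would also appear with a carboxylic acid, a methyl ester or an amine at the same place. Also open, from the compounds shown here alone, is whether a longer chain on the carbonyl, as in propionyl, would keep the number seen for compound 3.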